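A few compounds are considered here, and "the series" means these few. Any claim that something is new, unique, unknown or untested is made for them only; others in the source may bear on it.

The study measures cytotoxicity in a functional assay on cells (Rhabdomyosarcoma cell, Homo sapiens) for cytotoxicity (a higher number here means a weaker inhibitor, a lower number a stronger inhibitor), across a small set of compounds that share one core. Compound 1 `Cc1ccccc1C(c1sccc1C)N1CCN(c2ncnc3c2cnn3-c2ccccc2)CC1` sits at the limit of the assay with > 25000 nM, which is a limit and not a number. Compound 2 `c1ccc(C(c2nccs2)N2CCN(c3ncnc4c3cnn4-c3ccccc3)CC2)cc1` likewise returns only a limit, > 25000 nM. Compound 3 `N#Cc1cccc(C(c2ccccc2)N2CCN(c3ncnc4c3cnn4-c3ccccc3)CC2)c1` also gives a limit, > 25000 nM. Within the data shown here, the one step that joins two of these measured compounds, a step that the two limits leave unreadable from compound 2 to compound 3, cannot be read in size, since both ends are limits. Compound 3 therefore stands only at a limit, and the two further values shown are limits as well; the limit of > 25000 nM in this assay, at which 3 of the 3 values shown sit, describes where all three rest.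

Compound 4 `Cc1ccccc1C(c1ccccc1)N1CCN(c2ncnc3c2cnn3-c2ccccc2)CC1` has not been measured yet. It differs from compound 3 in one place: 2-methylphenyl in place of 3-cyanophenyl on a saturated chain carbon bound to an amine nitrogen in a ring and an aromatic carbon. Among the measured compounds shown here, no measured step with a readable size bears on this change. Compound 1 carries the same 2-methylphenyl group on the saturated chain carbon and returned only a limit, so the change is expected to leave compound 4 at the limit as well. The step that the limit leaves unreadable from compound 3 to compound 4 is expected to be none beyond the scatter. Compound 4 is estimated at 35000 nM, with a range from 15000 nM to 100000 nM.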

Compound 4, half-maximal inhibitory concentration: > 25000 nM
Compound 4 gave a limit, no number; the forecaster's own chance of this, stated with the estimate: 85%; the middle value lies beyond the limit too.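

In this assay compound 4 gives > 25000 nM, which is a limit and not a number. None of the steps from compound 1, compound 2 or compound 3 to compound 4 can be read in size: each joins two limits. The compounds shown leave open which group on the saturated chain carbon, if any, would give a measurable value, with all of them resting at one limit: the limit of > 25000 nM in this assay, at which 4 of the 4 values shown sit.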